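The source may report more compounds than this note shows. Statements on the series, on what has been measured and on what is new or still open speak of the compounds shown alone.

Compound 1 `O=C(CCCCCCCCCc1ccccc1)N1CCCCC1`: > 100000 nM
Compound 2 `N#Cc1ccc(CCCCCCCCC(=O)N2CCCCC2)cc1`: > 100000 nM
Compound 3 `COc1ccc(CCCCCCCCC(=O)N2CCCCC2)cc1`: not yet measured

In a functional assay on PANC-1 cells (Homo sapiens) for cytotoxicity, read by WST assay, with a stated time of 24 h (on this read-out higher numbers stand for weaker inhibition and lower numbers for stronger inhibition), compound 2 stands at > 100000 nM, which is a limit and not a number. Compound 1 at > 100000 nM is likewise a limit. Compound 3 carries methoxy in place of cyano on an aromatic carbon, with methoxy in place of cyano on an aromatic carbon. Among the measured compounds shown here, the only measured step bearing on this is a step that the two limits leave unreadable from compound 1 to compound 2, and the only anchor is the limit of > 100000 nM in this assay, at which 2 of the 2 values shown sit. No step beyond the scatter is therefore expected in this assay, and the expected step is a number no higher from compound 2 to compound 3 (the limit leaves the size open). Compound 3 is estimated at 100000 nM, with an expected range of 50000 nM to 200000 nM.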

Compound 3, half-maximal inhibitory concentration: 89300 nM
Compound 3: the middle estimate sits 1.1-fold (0.05 log units) above what was measured; the range from low to high includes it.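

In this assay, among the compounds shown here, compound 3 gives 89300 nM, the only value shown that is a number and not a limit, so a substituent at this position can now be placed on the scale. The steps are an at least 1.1-fold lower number from compound 2 to compound 3 (0.04 log units; that floor lies within the scatter) and an at least 1.1-fold lower number from compound 1 to compound 3 (0.04 log units; that floor lies within the scatter), so methoxy in place of cyano shows nothing beyond the scatter. Their true size stays open: the limit of > 100000 nM in this assay, at which 2 of the 3 values shown sit.

The step from compound 1 to compound 2 cannot be read. Going by these compounds, whether an amine or a carboxylic acid on the aromatic carbon, or a longer chain, would give a value well clear of the limit stays open.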